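The compounds below may be only part of what the source reports. "The series", "measured", "known", "first", "only" and "open" are said of these compounds alone.

Compounds measured so far in a functional assay on MCF7 cells (Homo sapiens) for antiproliferative activity, read by MTT assay, with a stated time of 72 h; a lower number here means a stronger inhibitor, a higher number a weaker inhibitor:
Compound 1 `COc1ccc(-c2cn(C[C@H](O)[C@H]3OC(=O)C(OCc4ccccc4)=C3OCc3ccccc3)nn2)cc1` gives 99700 nM.
Compound 2 `O=C1O/C(=C\Cn2cc(-c3ccc(Br)cc3)nn2)C(OCc2ccccc2)=C1OCc1ccccc1` gives only a limit of this assay, > 100000 nM.
Compound 3 `COc1ccccc1-c1cn(C/C=C2\OC(=O)C(OCc3ccccc3)=C2OCc2ccccc2)nn1` likewise gives only a limit of this assay, > 100000 nM.

Among the measured compounds shown here, compound 1 thus stands as the single numbered value in the set, and it sits close to the limit of > 100000 nM in this assay, at which 2 of the 3 values shown sit, where the two other compounds rest. For the measured compounds named here, the one measured step, a step that the two limits leave unreadable from compound 2 to compound 3, cannot be read because both of its ends sit at the limit of > 100000 nM in this assay, at which 2 of the 3 values shown sit.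

Compound 4 `O=C1O[C@H]([C@@H](O)Cn2cc(-c3ccc(Br)cc3)nn2)C(OCc2ccccc2)=C1OCc1ccccc1` differs from compound 1 by bromo in place of methoxy on an aromatic carbon. Going by the values given here, no measured step concerns this exchange: the step between compound 2 and compound 3 involves 2-methoxyphenyl against 4-bromophenyl and gives no readable size. With compound 1 already near the limit, no step beyond the scatter is expected, and a report of only a limit is as likely as a number. Compound 4 is therefore estimated at 110000 nM, with a range from 40000 nM to 300000 nM. The expected step of a 1.1-fold higher number from compound 1 to compound 4 (0.04 log units; within the scatter) is within the usual scatter.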

Compound 4, half-maximal inhibitory concentration: 5620 nM
Beside the measured number, compound 4's estimate is 20-fold (1.29 log units) above it, and the stated range ends above it.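

In this assay, bromo in place of methoxy on an aromatic carbon, para to a large group, gives an 18-fold lower number from compound 1 to compound 4 (1.25 log units; beyond the scatter), the first readable size for a change at this position. Among the compounds shown here, the one earlier step has a limit at both ends and cannot be read, so the earlier compounds gave no sign that this position could shift the number at all. Compound 4 now gives the series a value well clear of the point where other compounds rest: the limit of > 100000 nM in this assay, at which 2 of the 4 values shown sit.

On these data alone, how other groups at this position would read, for example chloro, an amine or a carboxylic acid, stays open, so the step cannot yet be assigned to bromo entering or to methoxy leaving. Compound 2 also carries 4-bromophenyl and gives only a limit, > 100000 nM, which leaves open what the rest of the chain contributes.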